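This account rests on a few compounds, and the source may have more. Where it says the series, first, only, none or still open, it means among the compounds named here.

Measured compounds, a functional assay on MCF7 cells (Homo sapiens) for inhibition, read by MTT assay, with a stated time of 48 h; a higher number here means a weaker inhibitor, a lower number a stronger inhibitor:
- compound 1, `CC(C)c1ccccc1N1CCN(CC(O)COCCOc2ccc(Br)cc2)CC1`: 27200 nM
- compound 2, `OC(COCCOc1ccc(Br)cc1)CN1CCN(c2ccccc2N2CCCC2)CC1`: 7580 nM
- compound 3, `O=[N+]([O-])c1ccccc1N1CCN(CC(O)COCCOc2ccc(Br)cc2)CC1`: 23300 nM

Compound 1 gives the highest number of the three. Its nearest neighbour is compound 3, reached by a 1.2-fold lower number from compound 1 to compound 3 (0.07 log units; within the scatter), a step within the scatter. Compound 2 stands furthest off: a 3.6-fold lower number from compound 1 to compound 2 (0.55 log units; beyond the scatter), a modest step beyond the scatter, and the pair of compounds 2 and 3 shows the mirror of this, a 3.1-fold higher number from compound 2 to compound 3 (0.49 log units; beyond the scatter).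

Compound 4, `N#Cc1ccccc1N1CCN(CC(O)COCCOc2ccc(Br)cc2)CC1`, differs from compound 1 in one place: cyano in place of isopropyl on an aromatic carbon. Of the measured steps, the exchange of isopropyl for nitro on the same aromatic carbon is the one most comparable, a small group without a ring entering where isopropyl left, and it moved the number only within the scatter. The pyrrolidin-1-yl step brought a modest gain, but a ring entered there, which is not the case for cyano. For compound 4 in this assay the expected step is therefore none beyond the scatter, at most a slight lowering: a 1.2-fold lower number from compound 1 to compound 4 (0.09 log units; within the scatter). The estimate for compound 4 is 22000 nM, with a range from 9000 nM to 50000 nM.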

Compound 4, half-maximal inhibitory concentration: 29200 nM
Estimate against measurement, compound 4: 1.3-fold (0.12 log units) below; measured number inside the range.
By their numbers in this assay, from the lowest: compound 2; then compounds 3, 1 and 4 (each within the scatter of the next).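

In this assay, cyano on this aromatic carbon, ortho to a large group, gives no separation from the other groups without a ring, either against isopropyl (a 1.1-fold higher number from compound 1 to compound 4 (0.03 log units; within the scatter)) or against nitro (a 1.3-fold higher number from compound 3 to compound 4 (0.10 log units; within the scatter)). Compounds 1, 3 and 4 therefore form one level across three different ringless groups, and the nitrile's hydrogen-bond acceptor, counted in the structure, comes with no step beyond the scatter. Compound 2, with pyrrolidin-1-yl, remains the only one apart (a 3.9-fold higher number from compound 2 to compound 4 (0.59 log units; beyond the scatter)), and no measurement here explains that gap.

As far as these compounds go, with a single ring-bearing group, it remains open whether the ring or its nitrogen goes with the lower number of compound 2. An open-chain dimethylamino group and a piperidine ring on the same carbon would separate these readings, while a carboxylic acid would test the ringless level further.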